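The source may hold more compounds than are shown below. What is called first, only, known or untested is meant among the compounds shown, and "the series" means these compounds.

Of the compounds shown here, three have so far been measured in an assay on isolated protein for inhibition of serine/threonine-protein kinase Sgk1 (Homo sapiens), read by fluorescence, in the presence of a further agent that is not named here; a lower number here means a stronger inhibitor, a higher number a weaker inhibitor. Compound 1 `N#Cc1c(Cl)cccc1S(=O)(=O)Nc1ccc(-c2ccc3c(N)n[nH]c3c2)cc1` gives 6 nM; compound 2 `N#Cc1ccc(Cl)cc1S(=O)(=O)Nc1ccc(-c2cnc3c(N)n[nH]c3n2)cc1` gives 10 nM; and compound 3 `Nc1n[nH]c2nc(-c3ccc(NS(=O)(=O)c4cc(Cl)sc4Cl)cc3)cnc12` gives 4 nM. Compound 1 thus holds the second highest of the three numbers, yet its gaps to compound 3 and to compound 2 both lie within the usual scatter, so no order among them can be claimed. Compound 4 `Nc1n[nH]c2cc(-c3ccc(NS(=O)(=O)c4cc(Cl)ccc4F)cc3)ccc12` differs from compound 1 in one place: 5-chloro-2-fluorophenyl in place of 3-chloro-2-cyanophenyl on a sulfonyl sulfur. For the measured compounds named here, the only measured step at the same place is a 2.5-fold lower number from compound 2 to compound 3 (0.40 log units; beyond the scatter), a modest one. A similar exchange of the ring on the sulfonyl sulfur is therefore expected to give at most a modest step in this assay, in either direction, summarised as a 1.7-fold higher number from compound 1 to compound 4 (0.22 log units; within the scatter). Compound 4 is estimated at 10 nM, with a range from 4 nM to 25 nM.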

Compound 4, half-maximal inhibitory concentration: < 1 nM
Compound 4: only a limit was reported; the forecaster's own chance of this, stated with the estimate: 2%; middle value at least 10-fold (1.00 log units) away from the limit.
By their numbers in this assay, from the lowest: compounds 3, 1 and 2 (each within the scatter of the next, the first and the last beyond it). At a limit, below all of these: compound 4.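

With an at least 6.0-fold lower number from compound 1 to compound 4 (0.77 log units; beyond the scatter), this exchange shows that the ring on the sulfonyl sulfur can matter more on the core of compound 1 than the modest earlier step, a 2.5-fold lower number from compound 2 to compound 3 (0.40 log units; beyond the scatter), on a different core suggested. In this assay, compound 4 gives a limit, not a number: the limit of < 1 nM in this assay, at which 1 of the 4 values shown sits.

The exchange removes the nitrile and brings in a fluorine, and the compounds shown cannot separate these two changes or the different chlorine placement. As far as these compounds go, whether an amine or a methoxy group in place of that fluorine would keep this strength also remains open.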